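Swapping the Aryl Group of Compound 1 for Compound 3

The source may hold more compounds than are shown below. What is called first, only, known or untested is meant among the compounds shown, and "the series" means these compounds.

Compound 1 `CN(C)c1ccc(/C=C(/SCc2ccc(F)cc2)C(=O)c2ccc(Br)cc2)cc1` was tested in a functional assay on DU-145 cells (Homo sapiens) for inhibition, read by trypan blue exclusion, with a stated time of 96 h (on this read-out lower numbers stand for stronger inhibition of growth and higher numbers for weaker inhibition of growth), where compound 1 gives 50000 nM. Compound 2 `COc1ccc(/C=C(\C(=O)c2ccc(Cl)cc2)S(=O)(=O)Cc2ccccc2Cl)cc1` gives 50000 nM in this assay, so compound 1 stands level with compound 2, within the scatter. Compound 3 `Cc1cc(F)ccc1/C=C(/SCc1ccc(F)cc1)C(=O)c1ccc(Br)cc1` differs from compound 1 as follows: 4-fluoro-2-methylphenyl in place of 4-(dimethylamino)phenyl on a double-bonded chain carbon bound to a double-bonded chain carbon. For the measured compounds named here, no measured step of this kind exists to lean on, and with compound 1 sitting at 50000 nM, no change beyond the scatter is expected in this assay. The step expected here is a 1.3-fold lower number from compound 1 to compound 3 (0.10 log units; within the scatter). Compound 3 is estimated at 40000 nM, with a range from 8000 nM to 60000 nM.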

Compound 3, concentration for 50% growth inhibition: 10000 nM
For compound 3 the middle estimate is 4.0-fold (0.60 log units) above the measured one, within the range that was stated.
By their numbers in this assay, from the lowest: compound 3; then compounds 1 and 2 (each within the scatter of the next).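

In this assay, for the compounds shown here, the group on this double-bonded chain carbon matters: 4-fluoro-2-methylphenyl in place of 4-(dimethylamino)phenyl gives a 5.0-fold lower number from compound 1 to compound 3 (0.70 log units; beyond the scatter) and is the only step here between compounds that differ in one place. The step is modest, but it shows that growth inhibition in this series can shift with this aryl group. Nothing measured here accounts for the change. On these data alone, the swap replaces the whole aryl group, so the separate roles of the dimethylamino, fluoro and methyl groups stay open. As far as these compounds go, how a morpholine or a carboxylic acid would fare at this place also remains open.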